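The source may hold more compounds than are shown below. What is called first, only, known or untested is meant among the compounds shown, and "the series" means these compounds.

Measured compounds:
compound 1, `CC(=O)N(C)c1ccc2[nH]c(-c3n[nH]c4ccccc34)cc2n1`, 23400 nM
compound 2, `CN(C(=O)CCc1ccccc1)c1ccc2[nH]c(-c3n[nH]c4ccccc34)cc2n1`, 20900 nM
compound 3, `CN(C(=O)c1ccc(F)cc1)c1ccc2[nH]c(-c3n[nH]c4ccccc34)cc2n1`, 9150 nM

In a functional assay on SMMC-7721 cells (Homo sapiens) for antiproliferative activity, read by MTT assay, with a stated time of 72 h (a lower number here means a stronger inhibitor, a higher number a weaker inhibitor), compound 1 gives the highest number of the three; compound 2 sits within the scatter of it (a 1.1-fold lower number from compound 1 to compound 2 (0.05 log units; within the scatter)), while compound 3 lies beyond it (a 2.6-fold lower number from compound 1 to compound 3 (0.41 log units; beyond the scatter)). Compound 4, `CN(c1ccc2[nH]c(-c3n[nH]c4ccccc34)cc2n1)S(=O)(=O)c1ccccc1`, is not yet measured. Its change from compound 1 is phenylsulfonyl in place of acetyl on a nitrogen on an aromatic ring. Going by the values given here, the steps that bear on it are those bringing an aromatic ring onto the carbonyl carbon, a 2.6-fold lower number from compound 1 to compound 3 (0.41 log units; beyond the scatter) and a 2.3-fold lower number from compound 2 to compound 3 (0.36 log units; beyond the scatter), both modest and both toward a lower number. Among the compounds with values here, the entering phenylsulfonyl also carries an aromatic ring, but no measured pair tests a sulfonyl in place of a carbonyl. For compound 4 a modest step toward a lower number is therefore expected, a 2.1-fold lower number from compound 1 to compound 4 (0.33 log units; beyond the scatter). Compound 4 is estimated at 11000 nM, with a range of 4000 nM to 30000 nM.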

Compound 4, half-maximal inhibitory concentration: 12000 nM
For compound 4 the middle estimate is 1.1-fold (0.04 log units) below the measured one; low and high end bracket the measured number.
By their numbers in this assay, from the lowest: compounds 3, 4, 2 and 1 (each within the scatter of the next, the first and the last beyond it).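

In this assay, compound 4 shows that a sulfonyl can stand in place of the carbonyl on this nitrogen on an aromatic ring without a step beyond the scatter: a 2.0-fold lower number from compound 1 to compound 4 (0.29 log units; within the scatter) and a 1.7-fold lower number from compound 2 to compound 4 (0.24 log units; within the scatter) and also a 1.3-fold higher number from compound 3 to compound 4 (0.12 log units; within the scatter). The change therefore separates compound 4 from none of the three amides, even though compound 3 and compound 1 lie beyond the scatter of each other. No measured evidence bears on this result.

Still open, as far as these compounds go, is how a methylsulfonyl group, which would separate the sulfonyl from its phenyl ring, would compare with the acetyl of compound 1. A 4-fluorophenylsulfonyl group would likewise give a direct match to the (4-fluorophenyl)carbonyl of compound 3.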